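The compounds below may be only part of what the source reports. "The series", "measured", "known", "first", "only" and "open" are said of these compounds alone.

Compound 1, `C=C(C)C(=O)c1ccc(OCc2nc(-c3ccc([N+](=O)[O-])cc3)no2)cc1C`, gives in an assay on HL-60 cells for inhibition of glutathione S-transferase P (Homo sapiens) (a higher number here means a weaker inhibitor, a lower number a stronger inhibitor), the value 2900 nM.
Compound 2, `C=C(C)C(=O)c1ccc(OCc2nc(C)no2)c(C)c1C`, gives in this assay the value 4000 nM.
Compound 3, `C=C(C)C(=O)c1ccc(OCc2nc(-c3ccc(Cl)cc3)no2)c(C)c1C`, gives in this assay the value 2000 nM.

Compound 3 has the lowest of the three numbers, yet its gaps to compound 1 and to compound 2 both lie within the scatter, so no order among the three can be claimed. Compound 4, `C=C(C)C(=O)c1ccc(OCc2nc(-c3ccc([N+](=O)[O-])cc3)no2)c(C)c1C`, is not yet measured. It differs from compound 3 by nitro in place of chloro on an aromatic carbon. Within the data shown here, no measured step shows this exact exchange. Among the measured compounds shown here, the only step among the measured compounds, a 2.0-fold lower number from compound 2 to compound 3 (0.30 log units; within the scatter), concerns the group on the same ring but is a different exchange. Compound 1 carries the nitro-substituted group that enters here on a core that differs elsewhere, and its value sits within the scatter of compound 3. On these grounds a step of about a 1.3-fold higher number from compound 3 to compound 4 (0.10 log units; within the scatter) is expected, that is, nothing beyond the scatter. Compound 4 is therefore estimated at 2500 nM, within 1200 nM to 5500 nM.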

Compound 4, half-maximal inhibitory concentration: 2300 nM
Beside the measured number, compound 4's estimate is 1.1-fold (0.04 log units) above it, within the range that was stated.
By their numbers in this assay, from the lowest: compounds 3, 4, 1 and 2 (each within the scatter of the next).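

The exchange of chloro for nitro on this aromatic carbon, the first direct test at this position, gives a 1.2-fold higher number from compound 3 to compound 4 (0.06 log units; within the scatter) in this assay, so the three heavy atoms and two hydrogen-bond acceptors of nitro do not separate the two compounds here. The other two new comparisons also stay inside the scatter: 4-nitrophenyl in place of methyl gives a 1.7-fold lower number from compound 2 to compound 4 (0.24 log units; within the scatter), and methyl in place of hydrogen on an aromatic carbon gives a 1.3-fold lower number from compound 1 to compound 4 (0.10 log units; within the scatter). No supporting data are available to explain these results.

As far as these compounds go, it remains open whether an amine or a carboxylic acid in place of chloro or nitro would move the number beyond the scatter. Also open, from the compounds shown here alone, is whether methyl in place of hydrogen would give a similar step with 4-chlorophenyl on the core.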